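A few compounds are considered here, and "the series" means these few. Any claim that something is new, unique, unknown or untested is made for them only; others in the source may bear on it.

In a functional assay on RPMI-8226 cells (Homo sapiens) for antiproliferative activity, read by radiometric assay, with a stated time of 72 h (a lower number here means a stronger inhibitor, a higher number a weaker inhibitor), compound 1 `Cc1ccc(F)c(Nc2ncnc3cc(NC(=O)CCCCCCC(=O)NO)sc23)c1` gives 1060 nM, compound 2 `CCc1cccc(Nc2ncnc3cc(NC(=O)CCCCCCC(=O)NO)sc23)c1` gives 1570 nM and compound 3 `C#Cc1cccc(Nc2ncnc3cc(NC(=O)CCCCCCC(=O)NO)sc23)c1` gives 970 nM. Compound 3 thus stands level with both of the others. Compound 4 `N#Cc1cccc(Nc2ncnc3cc(NC(=O)CCCCCCC(=O)NO)sc23)c1` carries cyano in place of ethynyl on an aromatic carbon, meta to a large group (cyano in place of ethynyl on an aromatic carbon). For the measured compounds named here, no measured step makes this exact exchange. The closest one, ethynyl in place of ethyl on an aromatic carbon, is a 1.6-fold lower number from compound 2 to compound 3 (0.21 log units; within the scatter). The other two steps, a 1.5-fold higher number from compound 1 to compound 2 (0.17 log units; within the scatter) and a 1.1-fold lower number from compound 1 to compound 3 (0.04 log units; within the scatter), are similarly small, so no step beyond the scatter is expected in this assay. The estimated change is a 1.1-fold higher number from compound 3 to compound 4 (0.05 log units; within the scatter). Compound 4 is expected at 1100 nM, within an estimated range of 550 nM to 2200 nM.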

Compound 4, half-maximal inhibitory concentration: 1580 nM
The estimate for compound 4 lay 1.4-fold (0.16 log units) below the measured number; low and high end bracket the measured number.
By their numbers in this assay, from the lowest: compounds 3, 1, 2 and 4 (each within the scatter of the next).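

In this assay, cyano on this aromatic carbon, meta to a large group, brings a hydrogen-bond acceptor that ethynyl and ethyl lack, yet the number stays within the scatter of both (a 1.6-fold higher number from compound 3 to compound 4 (0.21 log units; within the scatter); a 1.0-fold higher number from compound 2 to compound 4 (0.00 log units; within the scatter)). The exchange of the whole ring substituent for 3-cyanophenyl also stays within the scatter (a 1.5-fold higher number from compound 1 to compound 4 (0.17 log units; within the scatter)), so a nitrogen-bearing group here behaves like the all-carbon groups among these compounds. No measurement at hand offers a reason for these small steps. On these data alone, whether an amine, a carboxylic acid or a longer chain at this position would move the number beyond the scatter remains open.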